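Stereochemistry of a Bicyclic Acetal Series and Growth Inhibition

The source may report more compounds than this note shows. Statements on the series, on what has been measured and on what is new or still open speak of the compounds shown alone.

Compound 1 `CC(=O)OC1OC=CC2C1CC[C@H]2O` and compound 2 `CC(=O)O[C@@H]1OC=C[C@@H]2[C@H]1[C@@H](C)C[C@H]2O[Si](c1ccccc1)(c1ccccc1)C(C)(C)C` share a bicyclic acetal core and were both tested in a functional assay on WiDr cells (Homo sapiens) for antiproliferative activity, read by sulforhodamine B assay, with a stated time of 48 h; a higher number here means a weaker inhibitor of growth, a lower number a stronger inhibitor of growth. Compound 1 gives 16000 nM in this assay, while compound 2 gives 1260 nM, the lower of the two numbers; the gap between them lies beyond the usual scatter of repeated measurements, so compound 2 is the stronger growth inhibitor of the pair. Compound 3 `CC(=O)O[C@H]1OC=C[C@H]2[C@@H]1[C@H](C)C[C@H]2O[Si](c1ccccc1)(c1ccccc1)C(C)(C)C` has not yet been measured. It differs from compound 2 in configuration only: the two compounds have the same atoms and bonds and differ only in configuration as drawn: 4 of 5 stereo elements differ; a stereocentre at a saturated ring carbon is drawn S in compound 2 and R in compound 3; a stereocentre at a saturated ring carbon is drawn R in compound 2 and S in compound 3; a stereocentre at a saturated ring carbon is drawn R in compound 2 and S in compound 3; a stereocentre at a saturated ring carbon is drawn S in compound 2 and R in compound 3. Within the data shown here, since no measured pair in this set isolates such a change, there is no direct precedent to lean on. A change in spatial arrangement at several ring carbons can shift activity in either direction, and a weakening is the more common outcome, so compound 3 is expected to show a step of a 4.0-fold higher number from compound 2 to compound 3 (0.60 log units; beyond the scatter) relative to compound 2. The estimated value for compound 3 in this assay is 5000 nM, with a plausible range from 1000 nM to 25000 nM.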

Compound 3, concentration for 50% growth inhibition: 1130 nM
Beside the measured number, compound 3's estimate is 4.4-fold (0.65 log units) above it, and the stated range covers the measured number.
By their numbers in this assay, from the lowest: compounds 3 and 2 (each within the scatter of the next); then compound 1.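

In this assay, among these compounds, the result is a 1.1-fold lower number from compound 2 to compound 3 (0.05 log units; within the scatter), the first step in this set that isolates a change in configuration. Four of the five stereo elements differ at once, yet the two numbers stand within the scatter of each other, so in this assay growth inhibition by this pair does not distinguish the two spatial arrangements. The comparison is a clean one, with no atom or bond entering or leaving, and the sole difference is this: the fact that compounds 2 and 3 differ only in the configuration as drawn

From the compounds shown here alone, the four centres changed together, so what a change at any single ring carbon would do on its own remains open. Compound 1 differs from both in more than one place, which leaves open what sets its number apart, and how an amine or a longer chain on the shared core would read in this assay is also unknown.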